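The source may report more compounds than this note shows. Statements on the series, on what has been measured and on what is new or still open speak of the compounds shown alone.

Measured so far:
compound 1 `COc1cc(C2CC(c3ccc(Br)cc3)=NN2C(C)=O)cc(OC)c1OC` gives 4530 nM in a functional assay on HEp-2 cells (Homo sapiens) for cytotoxicity, read by sulforhodamine B assay, with a stated time of 48 h; a higher number here means a weaker inhibitor, a lower number a stronger inhibitor;
compound 2 `O=CCN1N=C(c2ccc3ccccc3c2)CC1c1ccccc1` gives 8400 nM in this assay;
compound 3 `O=CCN1N=C(c2ccc3ccccc3c2)CC1c1cccc([N+](=O)[O-])c1` gives 3870 nM in this assay.

Compound 3 and compound 1 lie within the scatter of each other in this assay. Against compound 2 the picture is clearer: a 2.2-fold lower number from compound 2 to compound 3 (0.34 log units; beyond the scatter), the only one-point step in the set.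

Compound 4 `O=CCN1N=C(c2ccc3ccccc3c2)CC1c1cccc(Cl)c1Cl` is not yet measured. The change from compound 3 is 2,3-dichlorophenyl in place of 3-nitrophenyl on a saturated ring carbon. Among the compounds with values here, the one measured step, from compound 2 to compound 3, concerns the same ring but a different substitution, so it bears on compound 4 only loosely: it shows that a change on that ring can move the number modestly in this assay, but gives no direct guide to two chlorines in place of nitro. Within the data shown here, no step in the set shows what such a swap does. The expectation for compound 4 is therefore a step within the scatter, a 1.1-fold lower number from compound 3 to compound 4 (0.04 log units; within the scatter), with wide uncertainty. Compound 4 is estimated at 3500 nM in this assay, range 1400 nM to 9000 nM.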

Compound 4, half-maximal inhibitory concentration: 12500 nM
Compound 4: the middle estimate sits 3.6-fold (0.55 log units) below what was measured; measured number outside the range, above it.
By their numbers in this assay, from the lowest: compounds 3, 1, 2 and 4 (each within the scatter of the next, the first and the last beyond it).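

In this assay, the aryl group on this saturated ring carbon still moves the number when one substituted ring replaces another: 2,3-dichlorophenyl in place of 3-nitrophenyl gives a 3.2-fold higher number from compound 3 to compound 4 (0.51 log units; beyond the scatter). Against the plain phenyl of compound 2, the same ring gives a 1.5-fold higher number from compound 2 to compound 4 (0.17 log units; within the scatter), a step within the scatter, so among these compounds only the 3-nitrophenyl ring stands apart from phenyl, and substitution on this ring does not in itself lower the number. Nothing available on these compounds accounts for the difference between the nitro and dichloro rings.

Open, on these data alone, is whether a single chlorine behaves like the pair in compound 4. Also open, as far as these compounds go, is whether an amine or a carboxylic acid in place of the nitro group would hold the number of compound 3.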